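From a Prenyl Ester to a Pyrrolidine Amide

This account rests on a few compounds, and the source may have more. Where it says the series, first, only, none or still open, it means among the compounds named here.

Of the compounds shown here, two have been measured in a functional assay on PC-3 cells (Homo sapiens) for cytotoxicity, read by MTT assay, with a stated time of 72 h; on this read-out lower numbers stand for stronger inhibition and higher numbers for weaker inhibition. Compound 1 `CCOC(=O)c1ccc(/C=C/C(=O)c2cc(OC)ccc2OC)cc1` gives 5700 nM in this assay. Compound 2 `COc1ccc(OC)c(C(=O)/C=C/c2ccc(C(=O)OCC=C(C)C)cc2)c1` reaches only the limit of this assay, > 50000 nM. Among the compounds with values here, the single measured step, an at least 8.7-fold higher number from compound 1 to compound 2 (0.94 log units; beyond the scatter), follows from 2-methylprop-1-en-1-yl in place of methyl on a saturated chain carbon bound to an oxygen next to a carbonyl group, and its size is bounded by the limit of > 50000 nM in this assay, at which 1 of the 2 values shown sits, rather than fixed.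

Compound 3 `COc1ccc(OC)c(C(=O)/C=C/c2ccc(C(=O)N3CCCC3)cc2)c1` awaits measurement and differs from compound 2 by pyrrolidin-1-yl in place of (3-methylbut-2-en-1-yl)oxy on a carbonyl carbon. Within the data shown here, no measured step covers an ester-to-amide exchange, so the expectation is loose. Because compound 1 gives 5700 nM with the shorter ester at this carbonyl, the guess for compound 3 is placed between the two measured points. Compound 3 is expected to give 15000 nM, within 4000 nM to 50000 nM. This corresponds to an estimated step of an at least 3.3-fold lower number from compound 2 to compound 3 (0.52 log units; beyond the scatter), with a real chance that only a limit is reported.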

Compound 3, half-maximal inhibitory concentration: 530 nM
For compound 3 the middle estimate is 28-fold (1.45 log units) above the measured one, and the stated range ends above it.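

In this assay, the group on the carbonyl carbon turns out to matter in both directions: putting pyrrolidin-1-yl in place of (3-methylbut-2-en-1-yl)oxy gives an at least 94-fold lower number from compound 2 to compound 3 (1.97 log units; beyond the scatter), and putting it in place of ethoxy gives an 11-fold lower number from compound 1 to compound 3 (1.03 log units; beyond the scatter). The earlier pair, which differed only in the ester chain, showed nothing but a loss, whereas the amide of compound 3 improves even on the better ester, compound 1. The first of these steps has only a lower bound on its size, set by a limit for compound 2 rather than a fixed number: the limit of > 50000 nM in this assay, at which 1 of the 3 values shown sits.

On these data alone, what remains open is whether the gain belongs to the pyrrolidine ring or to the amide as such. A piperidine amide, a diethylamide or a simple methylamide on the same carbonyl carbon would help to separate these two readings.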